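The source may hold more compounds than are shown below. What is called first, only, known or untested is meant among the compounds shown, and "the series" means these compounds.

In a physicochemical assay for solubility, read by HPLC, in simulated intestinal fluid, with a stated time of 16 h, at pH 6.5, tested at 2.5 mg/mL (on this read-out higher numbers stand for higher solubility and lower numbers for lower solubility), compound 1 `CNC(=O)c1cc(C(=O)N[C@H]2CC[C@H](O)CC2)cc2c1OC[C@@]2(C)c1ccccc1` gives >= 1000 ug/mL, which is a limit of the assay and not an exact number. Compound 2 `CC[C@@]1(c2ccccc2)COc2c(C(=O)NC)cc(C(=O)N[C@H]3[C@@H]4COC[C@@H]43)cc21` gives 93 ug/mL in this assay, so a related structure can read much lower. Compound 3 `CNC(=O)c1cc(C(=O)N[C@H]2C[C@@H]2C)cc2c1OC[C@@]2(C)c1ccccc1` carries 2-methylcyclopropyl in place of 4-hydroxycyclohexyl on an amide-type nitrogen, and the core of compound 1 stays otherwise the same. The expected step is a clear fall, beyond the usual scatter, estimated as an at least 5.8-fold lower number from compound 1 to compound 3 (0.76 log units; beyond the scatter). For compound 3 the estimated solubility is 170 ug/mL, with an expected range of 45 ug/mL to 650 ug/mL.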

Compound 3, solubility: 88 ug/mL
Compound 3: the middle estimate sits 1.9-fold (0.29 log units) above what was measured; low and high end bracket the measured number.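

In this assay compound 1 gives >= 1000 ug/mL, which is a limit of the assay and not an exact number. With the rest of the core of compound 1 unchanged, 2-methylcyclopropyl in place of 4-hydroxycyclohexyl on the amide-type nitrogen gives an at least 11-fold lower number from compound 1 to compound 3 (1.05 log units; beyond the scatter), a large step from a change in one place. That step is a bound and not an exact size because of where compound 1 stands: the limit of >= 1000 ug/mL in this assay, at which 1 of the 3 values shown sits.

The hydroxy group and the ring change together here, and the compounds shown do not tell which of them carries the step. A plain cyclohexyl or a 4-aminocyclohexyl on that nitrogen would speak to this.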